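Compound 2 to Compound 4: a Shorter Hydroxycarbamoyl Arm

A few compounds are considered here, and "the series" means these few. Any claim that something is new, unique, unknown or untested is made for them only; others in the source may bear on it.

Measured compounds:
compound 1, `C=CCN1CCC(c2noc(COc3ccc(/C=C/C(=O)NO)cc3)n2)CC1`, 66%;
compound 2, `O=C(/C=C/c1ccc(OCc2nc(C3CCN(Cc4ccccc4)CC3)no2)cc1)NO`, 71%;
compound 3, `O=C(/C=C/c1ccc(OCc2nc(C3CCN(Cc4ccccc4Cl)CC3)no2)cc1)NO`, 59%.

In an assay on isolated protein for inhibition of protein deacetylase HDAC6 (Homo sapiens), read by fluorescence, with a stated time of 1 h, tested at 100 nM (a higher number here means more inhibition at the concentration tested (going by the name of the read-out), a lower number less inhibition), compound 2 holds the highest of the three numbers. Its nearest neighbour is compound 1, at a number 5 percentage points higher from compound 1 to compound 2 (within the scatter), a gap within the scatter, so no order between these two can be claimed. Compound 3 lies furthest away, at a number 12 percentage points lower from compound 2 to compound 3 (beyond the scatter), a modest step beyond the scatter that follows chloro in place of hydrogen on an aromatic carbon. The remaining pair, compound 1 and compound 3, shows a number 7 percentage points lower from compound 1 to compound 3 (within the scatter), again within the scatter.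

Compound 4 is `O=C(NO)c1ccc(OCc2nc(C3CCN(Cc4ccccc4)CC3)no2)cc1`. It differs from compound 2 in one place:

hydroxycarbamoyl in place of 2-(hydroxycarbamoyl)ethenyl on an aromatic carbon

None of the three measured steps touches this part of the molecule; all of them change the group on the saturated chain carbon bound to the amine nitrogen in the ring. Among the measured compounds shown here, there is therefore no measured step to lean on, and the expectation for compound 4 rests only on the value of compound 2, 71%, with a wide range around it. Compound 4 is estimated at 60%, between 30% and 85%, which would mean an expected step of a number 11 percentage points lower from compound 2 to compound 4 (beyond the scatter) in this assay.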

Compound 4, a percentage reported as inhibition, at one concentration (the size of the read-out at that concentration, not a potency): 66%
For compound 4 the middle estimate is 6 percentage points below the measured one; the measured number falls inside the stated range.
By their numbers in this assay, from the lowest: compounds 3, 1, 4 and 2 (each within the scatter of the next, the first and the last beyond it).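

In this assay, among the compounds shown here, the first change at this position, hydroxycarbamoyl in place of 2-(hydroxycarbamoyl)ethenyl on the aromatic carbon para to a large group, gives a number 5 percentage points lower from compound 2 to compound 4 (within the scatter). The earlier compounds shown here all carried the same 2-(hydroxycarbamoyl)ethenyl group and differed only on the amine side, so they said nothing about this place; the new pair shows that going from 6 heavy atoms to 4 here, with the loss of the carbon-carbon double bond, leaves a reading that cannot be told apart from that of compound 2 at the one concentration tested. Nothing available offers an explanation for this result.

The compounds shown leave open how a saturated 2-(hydroxycarbamoyl)ethyl group or a longer chain ending in hydroxycarbamoyl would read at this aromatic carbon, and whether a carboxylic acid could stand in for the hydroxycarbamoyl group. They also leave open whether the same shortening would read alike with the vinyl of compound 1 or the 2-chlorophenyl of compound 3 on the amine side.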